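The source may hold more compounds than are shown below. What is called first, only, known or untested is meant among the compounds shown, and "the series" means these compounds.

Going by the values given here, compound 3 `Cc1ccc(C(=O)Nc2ccc(C(=O)/C=C/c3nc(C)c(C)nc3C)cc2)cc1` gives 5450 nM in a functional assay on HepG2 cells (Homo sapiens) for antiproliferative activity, read by CCK-8 assay, with a stated time of 72 h (a lower number here means a stronger inhibitor, a higher number a weaker inhibitor), the highest of the three numbers measured so far. Compound 2 `Cc1nc(C)c(/C=C/C(=O)c2ccc(NC(=O)c3ccccc3)cc2)nc1C` gives 1310 nM in this assay, and compound 1 `COc1cccc(OC)c1C(=O)Nc1ccc(C(=O)/C=C/c2nc(C)c(C)nc2C)cc1` gives 3380 nM. Compound 4 `COc1ccc(C(=O)Nc2ccc(C(=O)/C=C/c3nc(C)c(C)nc3C)cc2)cc1` differs from compound 3 by methoxy in place of methyl on an aromatic carbon. Among the compounds with values here, two measured steps bear on this change: a 4.2-fold higher number from compound 2 to compound 3 (0.62 log units; beyond the scatter) shows that placing a methyl on that aromatic carbon raised the number, while a 1.6-fold higher number from compound 1 to compound 3 (0.21 log units; within the scatter) shows that swapping a methoxy-bearing ring for the methylphenyl moved it only within the scatter. Within the data shown here, no measured step shows what a methoxy on that aromatic carbon does. Compound 4 is therefore expected to show a 1.4-fold lower number from compound 3 to compound 4 (0.13 log units; within the scatter), a step not beyond the scatter. The estimate for compound 4 in this assay is 4000 nM, ranging from 1500 nM to 11000 nM.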

Compound 4, half-maximal inhibitory concentration: 1190 nM
Estimate against measurement, compound 4: 3.4-fold (0.53 log units) above; measured number outside the range, below it.
By their numbers in this assay, from the lowest: compounds 4 and 2 (each within the scatter of the next); then compounds 1 and 3 (each within the scatter of the next).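

In this assay, the group at this place, para to a large group, clearly matters: swapping methyl for methoxy gives a clear gain (a 4.6-fold lower number from compound 3 to compound 4 (0.66 log units; beyond the scatter)). Methoxy here does not change the number beyond the scatter compared with the bare phenyl ring (a 1.1-fold lower number from compound 2 to compound 4 (0.04 log units; within the scatter)), so the loss seen with methyl is not shared by every group at this place. The single 4-methoxyphenyl also beats 2,6-dimethoxyphenyl (a 2.8-fold lower number from compound 1 to compound 4 (0.45 log units; beyond the scatter)).

Going by these compounds, how an amine, a hydroxyl or a longer chain such as ethoxy would behave at this place remains open. Nothing available explains why these steps differ.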